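This account rests on a few compounds, and the source may have more. Where it says the series, first, only, none or still open, it means among the compounds named here.

In an ADME assay on Vero cells (Chlorocebus sabaeus) for cytotoxicity, read by resazurin assay, with a stated time of 72 h (a lower number here means that less compound is tolerated, a higher number that more compound is tolerated), compound 1 `CC(C)(C)c1ccc(C(=O)/C=C/c2ccc([N+](=O)[O-])o2)cc1` gives a value that is only a limit, > 100000 nM. Going by the values given here, compound 2 `O=C(/C=C/c1ccc([N+](=O)[O-])s1)c1ccc(-n2ccnc2)cc1` gives 42700 nM in this assay, the only actual number among the values shown, the other being (the limit of > 100000 nM in this assay, at which 1 of the 2 values shown sits). Compound 3 `CCCCc1ccc(C(=O)/C=C/c2ccc([N+](=O)[O-])s2)cc1` has yet to be measured in this assay. It differs from compound 2 in one place: butyl in place of 1H-imidazol-1-yl on an aromatic carbon. Among the compounds with values here, no step between two measured compounds describes this change. Compound 1, which also carries an alkyl group in place of a ring at this position, sits at the limit with > 100000 nM, while compound 2 gives 42700 nM, so a shift toward higher tolerance beyond the scatter is expected for the step of a 1.8-fold higher number from compound 2 to compound 3 (0.24 log units; within the scatter). On this basis compound 3 is estimated at 75000 nM in this assay, expected to fall between 30000 nM and 150000 nM.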

Compound 3, half-maximal cytotoxic concentration: 81300 nM
Beside the measured number, compound 3's estimate is 1.1-fold (0.04 log units) below it, within the range that was stated.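

In this assay, going by these compounds alone, the exchange of 1H-imidazol-1-yl for butyl on an aromatic carbon of the six-membered aromatic ring gives a 1.9-fold higher number from compound 2 to compound 3 (0.28 log units; within the scatter), the first step at this position that can be read between two actual numbers. Within the data shown here, it shows that this position takes an open carbon chain in place of a five-membered aromatic ring with hydrogen-bond acceptors without a shift beyond the usual scatter, something the earlier compounds, which offered no single-place step, could not show. No measured property among the data shown accounts for this result. On these data alone, whether an amine, a carboxylic acid or a longer chain at this position would also stay within the scatter remains open. So does whether the same exchange would read alike on the core of compound 1.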